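A few compounds are considered here, and "the series" means these few. Any claim that something is new, unique, unknown or untested is made for them only; others in the source may bear on it.

In a functional assay on COLO 205 cells (Homo sapiens) for antiproliferative activity, read by sulforhodamine B assay, with a stated time of 72 h (on this read-out lower numbers stand for stronger inhibition and higher numbers for weaker inhibition), compound 1 (`O=S(=O)(Nc1ncccn1)c1ccc(Nc2nncc3ccccc23)cc1`) gives 43 nM. Compound 3 (`COc1ccc(NC(=S)NNc2nncc3ccccc23)cc1`) gives 67 nM, within the scatter of compound 1. Compound 2 (`Clc1ccc(C(/C=C/c2ccccc2)=N\Nc2nncc3ccccc23)cc1`) gives 5.7 nM, a number beyond the scatter below that of compound 1, so compound 1 sits with compound 3 at the weaker end of these three. Compound 4 (`NS(=O)(=O)c1ccc(Nc2nncc3ccccc23)cc1`) has hydrogen in place of pyrimidin-2-yl on a sulfonamide nitrogen. For the measured compounds named here, no measured pair isolates this change, so any expectation for it is tentative. A modest weakening in this assay is expected, and the estimated step of a 2.1-fold higher number from compound 1 to compound 4 (0.32 log units; beyond the scatter) may not clearly exceed the scatter. For compound 4 the estimated value is 90 nM, with an expected range of 20 nM to 400 nM.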

Compound 4, half-maximal inhibitory concentration: 23 nM
Compound 4: the middle estimate sits 3.9-fold (0.59 log units) above what was measured; the range from low to high includes it.
By their numbers in this assay, from the lowest: compound 2; then compounds 4, 1 and 3 (each within the scatter of the next, the first and the last beyond it).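

Hydrogen in place of pyrimidin-2-yl on a sulfonamide nitrogen gives a 1.9-fold lower number from compound 1 to compound 4 (0.27 log units; within the scatter) and so no step beyond the scatter. The six-membered aromatic ring of pyrimidin-2-yl is therefore not needed at this place to keep a number of this order in this assay, and the unsubstituted sulfonamide serves as well as the substituted one. No measurement at hand accounts for this result.

Still open, as far as these compounds go, is whether a methyl or an acetyl group on this nitrogen holds the number in the same range. From the compounds shown here alone, a carboxylic acid in place of the whole sulfonamide is equally open.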